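The source may report more compounds than this note shows. Statements on the series, on what has been measured and on what is new or still open speak of the compounds shown alone.

In an ADME assay on isolated protein for inhibition of Amine oxidase [flavin-containing] A (Homo sapiens), read by fluorescence and Amplex Red, with stated times of 15 min and 20 min (a lower number here means a stronger inhibitor, a higher number a weaker inhibitor), three compounds built on one shared core have been measured. Compound 1 `C#CCN(CCCCOc1ccc2ccc(=O)oc2c1)Cc1cccc(OC)c1` gives 78600 nM. Compound 2 `C#CCN(CCCCOc1ccc2ccc(=O)oc2c1)Cc1ccc(C(C)C)cc1` gives 35400 nM in this assay. Compound 3 `C#CCN(CCCOc1ccc2ccc(=O)oc2c1)Cc1ccc(C(C)C)cc1` gives 77400 nM in this assay. The numbers for compound 3 and compound 1 lie within the scatter of each other, so nothing separates them. The difference between the cores of compound 3 and compound 2 is not broken down here; what their values show is that compound 3 carries the higher number and compound 2 the lower one, a gap beyond the scatter.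

Between compound 2 and compound 1 a single change is made: 3-methoxyphenyl in place of 4-isopropylphenyl on a saturated chain carbon bound to an amine nitrogen. In this assay that change produced a 2.2-fold higher number from compound 2 to compound 1 (0.35 log units; beyond the scatter), a modest weakening of inhibition.

Compound 4 `C#CCN(CCCOc1ccc2ccc(=O)oc2c1)Cc1cccc(OC)c1` has not yet been measured. It arises from compound 3 by the same change, (3-methoxyphenyl in place of 4-isopropylphenyl on a saturated chain carbon bound to an amine nitrogen), made at a place described in exactly the same words, so it is the same change rather than merely one of the same kind. The step from compound 3 to compound 4 in this assay is expected to be about a 2.2-fold higher number from compound 3 to compound 4 (0.34 log units; beyond the scatter), because the identical change already gave a 2.2-fold higher number from compound 2 to compound 1 (0.35 log units; beyond the scatter) on the other core. On that basis compound 4 is estimated at 170000 nM, with a plausible range from 70000 nM to 400000 nM. A number this high may also run into the upper edge of what the assay can report.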

Compound 4, half-maximal inhibitory concentration: 22700 nM
Compound 4: the middle estimate sits 7.5-fold (0.87 log units) above what was measured; the measured number lies below the stated range.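

On the core of compound 3, putting 3-methoxyphenyl in place of 4-isopropylphenyl gave a 3.4-fold lower number from compound 3 to compound 4 (0.53 log units; beyond the scatter) in this assay, so here the change strengthened inhibition, whereas on the core of compound 2 it gave a 2.2-fold higher number from compound 2 to compound 1 (0.35 log units; beyond the scatter), a weakening. The effect of this change therefore did not carry from one core to the other, even in its direction: the same change on two cores in this assay, a 2.2-fold higher number (0.35 log units; beyond the scatter) from compound 2 to compound 1 and a 3.4-fold lower number (0.53 log units; beyond the scatter) from compound 3 to compound 4, 7.6-fold (0.88 log units) apart, beyond the scatter of two such steps Each direction rests on a single pair of compounds, so the result shows that the step depends on the core in this small set, but it gives no reason for the reversal and no rule for any other change in the series.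

The change also swaps two things at once, the group itself and its printed position on the ring, so a 4-methoxyphenyl or a 3-isopropylphenyl group would be needed to tell which of them matters on each core. From the compounds shown here alone, whether the order of the two groups would flip again on a core with a longer chain also remains open, as does how a ring carrying a nitrile or trifluoromethyl group would behave on either core.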